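The source may report more compounds than this note shows. Statements on the series, on what has been measured and on what is new or still open speak of the compounds shown alone.

Measured so far:
compound 1, `C#CCN(CCCC)Cc1cn(-c2cc(NC(=S)NCC)ncn2)cn1`: 20.1%
compound 2, `C#CCN(CC#N)Cc1cn(-c2cc(NC(=S)NCC)ncn2)cn1`: 15.4%

In an assay on isolated protein for inhibition of Amine oxidase [flavin-containing] B (Homo sapiens), read by fluorescence and Amplex Red, with a stated time of 15 min, tested at 50 uM (a higher number here means more inhibition at the concentration tested (going by the name of the read-out), a lower number less inhibition), compound 2 gives 15.4%, while compound 1 gives 20.1%, and the two numbers lie within the scatter of each other. Compound 3, `C#CCN1CCN(Cc2cn(-c3cc(NC(=S)NCC)ncn3)cn2)CC1`, differs from compound 2 by a group of 9 heavy atoms (7 carbon, 2 nitrogen; one six-membered non-aromatic ring with 2 hetero atoms) in place of a group of 7 heavy atoms (5 carbon, 2 nitrogen; no ring), on a saturated chain carbon bound to an aromatic carbon. Among the measured compounds shown here, the only measured step, a number 4.7 percentage points lower from compound 1 to compound 2 (within the scatter), bears on this only loosely, since it altered a different part of the same chain and stayed within the scatter. Compound 3 is therefore expected to shift by a number 0.4 percentage points lower from compound 2 to compound 3 (within the scatter), a step not beyond the scatter, and its estimated reading in this assay is 15%, between 5% and 28%.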

Compound 3, a percentage reported as inhibition, at one concentration (the size of the read-out at that concentration, not a potency): 13.3%
Compound 3: middle estimate off by 1.7 percentage points, on the high side, within the range that was stated.
By their numbers in this assay, from the lowest: compounds 3, 2 and 1 (each within the scatter of the next).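

Placing 4-propargylpiperazin-1-yl on a saturated chain carbon bound to an aromatic carbon puts a ring at this position for the first time, and in this assay this gives a number 2.1 percentage points lower from compound 2 to compound 3 (within the scatter) and a number 6.8 percentage points lower from compound 1 to compound 3 (within the scatter). Swapping either open chain for this ring therefore leaves the reading within the scatter, and the three compounds cannot be ranked. Nothing available explains these readings.

As far as these compounds go, whether a morpholine ring or a simple dimethylamino group here would move the reading beyond the scatter stays open. So does whether changes elsewhere on the shared core, such as to the thiourea, would do so.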